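Amide aryl swap on a triazole-thioether series

The source may hold more compounds than are shown below. What is called first, only, known or untested is meant among the compounds shown, and "the series" means these compounds.

Compound 1 `CC(C)Oc1ccc(NC(=O)CSc2nnc(Cc3nn(C)c(=O)c4ccccc34)n2C)cc1` — > 30000 nM
Compound 2 `Cn1c(Cc2nn(C)c(=O)c3ccccc23)nnc1SCC(=O)Nc1ccc(O)cc1` — "not active" (no number reported)
Compound 3 `COc1ccc(NC(=O)CSc2nnc(Cc3nn(C)c(=O)c4ccccc34)n2C)cc1` — "not active" (no number reported)

Of the compounds shown here, three sharing one core have been tested in an assay on isolated protein (Mus musculus) for inhibition of IL15-IL15 receptor (Homo sapiens), read by resazurin assay, with stated times of 30 min and 2.5 days; a lower number here means a stronger inhibitor, a higher number a weaker inhibitor. Compound 1 reaches only a limit of the assay, > 30000 nM, and that is all its entry tells. Compound 2 gives "not active" (no number reported) in this assay, with no number attached. Compound 3 stands in the same position: in this assay compound 3 gives "not active" (no number reported), so it has no single value. Compound 1 sits at a limit of > 30000 nM in this assay, at which 1 of the 3 values shown sits, and compound 2 carries no number either. No pair among these three differs in one place, so no step can be sized from them.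

Compound 4 `Cn1c(Cc2nn(C)c(=O)c3ccccc23)nnc1SCC(=O)Nc1ccc(F)cc1F` remains to be measured. It differs from compound 3 by 2,4-difluorophenyl in place of 4-methoxyphenyl on an amide-type nitrogen. Within the data shown here, with no measured step to lean on and every neighbour without a number, the expected outcome is no step beyond the scatter: compound 4 is estimated at 30000 nM, within 10000 nM to 100000 nM, most likely reported as a limit rather than a value.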

Compound 4, half-maximal inhibitory concentration: "not active" (no number reported)
Compound 4: no number reported; the estimate stays without a comparison.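

In this assay compound 4 gives no number, as compound 3 does, so no step can be read between them. The compounds shown leave open whether any group on the amide-type nitrogen gives measurable inhibition, as the only figure, that of compound 1, is a limit: the limit of > 30000 nM in this assay, at which 1 of the 4 values shown sits.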